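The source may hold more compounds than are shown below. What is called first, only, known or untested is meant among the compounds shown, and "the series" means these compounds.

Compound 1, `O=C(N/N=C/c1ccccc1)c1cccnc1Nc1cccc(C(F)(F)F)c1`, gives 21.2% in a functional assay on the whole organism (strain Wistar) for inhibition, with Rattus norvegicus as the target, read by paw edema, with a stated time of 3 h, at a dose of 10 mg/kg by the intraperitoneal route; on this read-out higher numbers stand for more inhibition at the one dose given (going by the name of the read-out) and lower numbers for less inhibition.
Compound 2, `O=C(N/N=C/c1ccc(F)cc1)c1cccnc1Nc1cccc(C(F)(F)F)c1`, gives 41.3%.
Compound 3, `O=C(N/N=C/c1ccc(Cl)cc1)c1cccnc1Nc1cccc(C(F)(F)F)c1`, gives 48.5%.

For the measured compounds named here, of the three numbers, that of compound 3 is the highest as written, yet the step of a number 7.2 percentage points higher from compound 2 to compound 3 (within the scatter) is within the scatter, so compounds 2 and 3 cannot be told apart on this read-out; only the step of a number 27.3 percentage points higher from compound 1 to compound 3 (beyond the scatter) lies beyond it.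

Compound 4, `COc1ccc(/C=N/NC(=O)c2cccnc2Nc2cccc(C(F)(F)F)c2)c(OC)c1`, differs from compound 3 by 2,4-dimethoxyphenyl in place of 4-chlorophenyl on a carbon with a double bond to nitrogen. Going by the values given here, no measured step tests a methoxy group or a second substituent on that ring. Among the compounds with values here, the steps that bear on it are those from the unsubstituted ring: a number 20.1 percentage points higher from compound 1 to compound 2 (beyond the scatter) and a number 27.3 percentage points higher from compound 1 to compound 3 (beyond the scatter), both modest and both beyond the scatter, while the exchange of one halogen for the other, a number 7.2 percentage points higher from compound 2 to compound 3 (within the scatter), stayed within it. The measured compounds therefore only show that a substituted ring scored higher than the bare one in this assay; they do not show whether a different substituent pattern moves the number further. Compound 4 is thus expected to land near compounds 2 and 3, with a step of a number 6.5 percentage points lower from compound 3 to compound 4 (within the scatter) expected to stay within the scatter, and the estimate for compound 4 is 42%, ranging from 22% to 60%.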

Compound 4, a percentage reported as inhibition, in the whole organism at one dose (the size of the read-out at that dose, not a potency): 24.1%
The estimate for compound 4 lay 17.9 percentage points above the measured number; measured number inside the range.
By their numbers in this assay, from the lowest: compounds 1 and 4 (each within the scatter of the next); then compounds 2 and 3 (each within the scatter of the next).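

In this assay, the carbon with a double bond to nitrogen turns out not to reward every substituted ring: 2,4-dimethoxyphenyl in place of 4-chlorophenyl gives a number 24.4 percentage points lower from compound 3 to compound 4 (beyond the scatter), and in place of 4-fluorophenyl it gives a number 17.2 percentage points lower from compound 2 to compound 4 (beyond the scatter). Set against the bare phenyl, the same group gives a number 2.9 percentage points higher from compound 1 to compound 4 (within the scatter), so the two methoxy groups leave the number indistinguishable from that of the unsubstituted ring. The earlier compounds shown here could suggest that any substituent on this ring lifts the number, but that holds only for the two halogen compounds, and compound 4 goes against it. Nothing measured here offers an explanation for this difference between the halogens and the two methoxy groups.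

The compounds shown leave open whether the loss belongs to the methoxy group itself or to the presence of two substituents, which a ring carrying one methoxy group could separate. They also leave open how this position would respond to a ring carrying a dimethylamino group or a carboxylic acid, or to a ring with two chloro groups.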